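A few compounds are considered here, and "the series" means these few. Any claim that something is new, unique, unknown or untested is made for them only; others in the source may bear on it.

The measured compounds and their numbers:

compound 1, `O=c1oc2ccc(I)cc2c(=O)n1-c1ccc(Cl)cc1F`: 8900 nM
compound 2, `O=c1oc2ccc(I)cc2c(=O)n1-c1ccc(I)cc1F`: 7600 nM
compound 3, `O=C(Nc1ccc(Cl)cc1F)c1cc(I)ccc1O`: 8500 nM

All three were tested in an ADME assay on RAW264.7 cells (Mus musculus) for cytotoxicity, read by MTT assay, with a stated time of 24 h; a lower number here means that less compound is tolerated, a higher number that more compound is tolerated. In this assay compound 1 gives 8900 nM, compound 2 gives 7600 nM and compound 3 gives 8500 nM; all three numbers sit within the usual scatter of one another, so no order among them can be read from these data.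

Compound 1 and compound 2 share a core and differ in one place: iodo in place of chloro on an aromatic carbon. That change made a 1.2-fold lower number from compound 1 to compound 2 (0.07 log units; within the scatter).

Compound 3 has a different core, and how the core of compound 3 differs from the core of compound 1 is not broken down here. The unmeasured compound 4, `O=C(Nc1ccc(I)cc1F)c1cc(I)ccc1O`, is built from compound 3 by a single change: iodo in place of chloro on an aromatic carbon. The description of the place is the same word for word as for the change from compound 1 to compound 2, so this is the same change applied on a second core.

Within the data shown here, for compound 4 the expected step is a 1.2-fold lower number from compound 3 to compound 4 (0.07 log units; within the scatter), because the one comparable change seen so far gave a 1.2-fold lower number from compound 1 to compound 2 (0.07 log units; within the scatter). Compound 4 is therefore estimated to give 7300 nM in this assay, with a likely range from 4000 nM to 14000 nM, since compound 3 stands at 8500 nM and the earlier step was small.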

Compound 4, half-maximal cytotoxic concentration: 6000 nM
For compound 4 the middle estimate is 1.2-fold (0.09 log units) above the measured one; the range from low to high includes it.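

In this assay, putting iodo in place of chloro on the core of compound 3 gave a 1.4-fold lower number from compound 3 to compound 4 (0.15 log units; within the scatter). Set beside the same change on the core of compound 1, the two steps cannot be told apart, so in this small set the change behaves alike on both cores: the same change on two cores in this assay, a 1.2-fold lower number (0.07 log units; within the scatter) from compound 1 to compound 2 and a 1.4-fold lower number (0.15 log units; within the scatter) from compound 3 to compound 4, 1.2-fold (0.08 log units) apart, within the scatter of two such steps This agreement does not show that iodo truly shifts the number on either core, since each step is itself within the scatter; what carries across is the absence of a readable effect, not an effect of a known size, and two cores cannot speak for the whole series.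

The compounds shown have only chloro or iodo at this place, so it stays open whether a quite different group there, such as an amine, a carboxylic acid or a longer chain, would move the number beyond the scatter, and whether it would do so equally on both cores. From the compounds shown here alone, it also stays open whether chloro and iodo would remain indistinguishable in any read-out other than this assay.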